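Aryl-substituent changes on a cytotoxic dienone series

The compounds below may be only part of what the source reports. "The series", "measured", "known", "first", "only" and "open" are said of these compounds alone.

Measured compounds:
compound 1, `CC1=C(/C=C/C(=O)/C=C/c2ccccc2F)C(C)(C)CCC1O`, 2900 nM
compound 2, `CC1=C(/C=C/C(=O)/C=C/c2cccc(C)c2)C(C)(C)CCC1O`, 4100 nM

Both compounds share one core and differ only in the aromatic ring at the far end of the chain. In a functional assay on LNCaP cells (Homo sapiens) for cytotoxicity, read by MTT assay, with a stated time of 72 h (on this read-out higher numbers stand for weaker inhibition and lower numbers for stronger inhibition), compound 1 gives 2900 nM, and compound 2 gives 4100 nM. Among the compounds with values here, the one measured step, a 1.4-fold higher number from compound 1 to compound 2 (0.15 log units; within the scatter), shows that exchanging the aryl ring leaves the read-out where it was. Compound 2 stands at the higher of the two numbers, but its gap to compound 1 is within the scatter, so no order between them can be claimed.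

Compound 3, `COc1cccc(/C=C/C(=O)/C=C/C2=C(C)C(O)CCC2(C)C)c1`, is not yet measured. Relative to compound 2 the change is methoxy in place of methyl on an aromatic carbon. Within the data shown here, no measured step covers this change on the ring; the only step available, from a fluorine-bearing to a methyl-bearing ring, was within the scatter. On that basis no movement beyond the scatter is expected: the step from compound 2 to compound 3 is estimated as a 1.0-fold lower number from compound 2 to compound 3 (0.01 log units; within the scatter). Compound 3 is therefore expected to give about 4000 nM, with a range from 1800 nM to 9000 nM.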

Compound 3, half-maximal inhibitory concentration: 4900 nM
Estimate against measurement, compound 3: 1.2-fold (0.09 log units) below; the range from low to high includes it.
By their numbers in this assay, from the lowest: compounds 1, 2 and 3 (each within the scatter of the next).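

In this assay, methoxy in place of methyl on this aromatic carbon, meta to a large group, gives a 1.2-fold higher number from compound 2 to compound 3 (0.08 log units; within the scatter), so adding an oxygen and a hydrogen-bond acceptor at this place does not separate the two compounds. The wider exchange of 2-fluorophenyl for 3-methoxyphenyl gives a 1.7-fold higher number from compound 1 to compound 3 (0.23 log units; within the scatter), which is also within the scatter, so the three aryl groups shown cannot be put in any order on this read-out, and the series so far shows no aryl change that moves the number beyond the scatter. No supporting measurement bears on why these compounds stay together, and none of the data speaks to how either group acts at this place.

From the compounds shown here alone, whether an amine, a carboxylic acid or a longer chain such as ethoxy on this aromatic carbon would move the number beyond the scatter remains open. Also open, going by these compounds, is whether the shared core, including its hydroxy group and the dienone chain, matters more to the read-out than the aryl group does.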